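Three Level Compounds and a Phenyl Swap

The source may hold more compounds than are shown below. What is called first, only, known or untested is meant among the compounds shown, and "the series" means these compounds.

Values measured so far in a functional assay on IGROV-1 cells (Homo sapiens) for inhibition, read by sulforhodamine B assay, with a stated time of 48 h; on this read-out higher numbers stand for weaker inhibition of growth and lower numbers for stronger inhibition of growth
- compound 1 `Cc1nnc(-c2nn(-c3ccccc3)c(-c3ccccc3)c2C#N)c2cn(-c3ccccc3)nc12` gives 92000 nM
- compound 2 `N#Cc1c(-c2nnc(O)c3nn(-c4ccccc4)cc23)nn(-c2ccccc2)c1-c1ccccc1` gives 92200 nM
- compound 3 `N#Cc1c(-c2nnc(O)c3nn(-c4ccc(Cl)cc4)cc23)nn(-c2ccccc2)c1-c1ccccc1` gives 91300 nM

Compound 2 stands level with the other two compounds, since all three numbers lie within the usual scatter of one another. The unmeasured compound 4 `N#Cc1c(-c2nnc(-c3ccccc3)c3nn(-c4ccccc4)cc23)nn(-c2ccccc2)c1-c1ccccc1` keeps the rest of compound 2 and differs in one group, with phenyl in place of hydroxy on an aromatic carbon.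

Within the data shown here, two measured steps bear on this change. The closer one, hydroxy in place of methyl, concerns the same carbon and gave a 1.0-fold higher number from compound 1 to compound 2 (0.00 log units; within the scatter). The other, chloro in place of hydrogen, lies elsewhere in the molecule and gave a 1.0-fold lower number from compound 2 to compound 3 (0.00 log units; within the scatter). Among the measured compounds shown here, neither step moved the number beyond the scatter, but no measured compound carries phenyl at this carbon, so the new group remains untested. On this evidence, no step beyond the scatter is expected in this assay, although a move towards a lower number is the likelier surprise. The expected change is a 1.2-fold lower number from compound 2 to compound 4 (0.06 log units; within the scatter) in this estimate. For compound 4 the estimated value is 80000 nM, with an expected range from 35000 nM to 110000 nM.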

Compound 4, concentration for 50% growth inhibition: 94800 nM
The estimate for compound 4 lay 1.2-fold (0.07 log units) below the measured number; low and high end bracket the measured number.
By their numbers in this assay, from the lowest: compounds 3, 1, 2 and 4 (each within the scatter of the next).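

Putting phenyl in place of hydroxy on this aromatic carbon gives a 1.0-fold higher number from compound 2 to compound 4 (0.01 log units; within the scatter) in this assay. This change removes a hydroxy group, with its hydrogen-bond donor and acceptor, and puts a six-membered aromatic ring of carbon only in its place, yet the number stays within the scatter, and phenyl in place of methyl likewise gives a 1.0-fold higher number from compound 1 to compound 4 (0.01 log units; within the scatter). Methyl, hydroxy and phenyl have now all been tested at this carbon, so even a much larger group here does not separate the compounds on this read-out, although nothing shown explains this lack of change.

The compounds shown leave open whether an amine or a carboxylic acid on this carbon, or a longer chain such as butyl, would move the number beyond the scatter. They also leave open whether any change at all to the shared core can give clearly stronger inhibition of growth, and so whether this carbon matters once a compound is more active.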